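A few compounds are considered here, and "the series" means these few. Any claim that something is new, unique, unknown or untested is made for them only; others in the source may bear on it.

Compound 3 `Cc1ccc2ncc(S(=O)(=O)c3ccc(Cl)cc3)c(N3CCC(C)CC3)c2c1` is measured in an assay on isolated protein for displacement of a labelled ligand from metabotropic glutamate receptor 5 (Homo sapiens), with a stated time of 60 min, tested at 1 uM (a higher number here means more inhibition at the concentration tested (going by the name of the read-out), a lower number less inhibition), where compound 3 gives 79%. Compound 1 `CC1CCN(c2c(S(=O)(=O)c3ccc(Cl)cc3)cnc3ccc(F)cc23)CC1` gives 80% and compound 2 `Cc1ccc2ncc(S(=O)(=O)c3ccc(F)cc3)c(N3CCC(C)CC3)c2c1` gives 90%, so compound 3 holds the lowest of the three numbers, though the step of a number 1 percentage points lower from compound 1 to compound 3 (within the scatter) lies within the scatter, while a number 11 percentage points lower from compound 2 to compound 3 (beyond the scatter) lies beyond it. Compound 4 `Cc1ccc2ncc(S(=O)(=O)c3ccc(C#N)cc3)c(N3CCC(C)CC3)c2c1` differs from compound 3 by cyano in place of chloro on an aromatic carbon. Within the data shown here, only the step from compound 2 to compound 3 touches the same aromatic carbon, and it was modest; nothing measured shows what cyano does there. A change of about that modest size, in either direction, is the most that is expected, namely a number 1 percentage points higher from compound 3 to compound 4 (within the scatter). Compound 4 is therefore estimated to give about 80% in this assay, between 66% and 92%.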

Compound 4, a percentage reported as inhibition, at one concentration (the size of the read-out at that concentration, not a potency): 55%
Compound 4: the middle estimate sits 25 percentage points above what was measured; measured number outside the range, below it.
By their numbers in this assay, from the lowest: compound 4; then compounds 3, 1 and 2 (each within the scatter of the next, the first and the last beyond it).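

This position is more sensitive than the swap of one halogen for another suggested: in this assay, cyano in place of chloro gives a clear drop (a number 24 percentage points lower from compound 3 to compound 4 (beyond the scatter)), and cyano in place of fluoro gives a larger one (a number 35 percentage points lower from compound 2 to compound 4 (beyond the scatter)). Of the three groups compared on this aromatic carbon, with the rest of the molecule unchanged, cyano gives the lowest number. No available evidence explains this drop.

Going by these compounds, it remains open whether methoxy or an amine on this carbon would keep the number near that of the halogen compounds. Whether cyano would cause a similar drop on the core of compound 1 is also open.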